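Piperazine in Place of Pyrazole on a Shared Core

The source may report more compounds than this note shows. Statements on the series, on what has been measured and on what is new or still open speak of the compounds shown alone.

Of the compounds shown here, three on one core have been tested so far. Compound 1 `O=c1nc(-c2ccccc2)c2cc(-c3ccc(F)cc3)ccc2[nH]1` carries a 4-fluorophenyl group; in an ADME assay on THP-1 cells (Homo sapiens) for cytotoxicity, read by MTT assay, with a stated time of 72 h (on this read-out lower numbers stand for an effect already at smaller amounts and higher numbers for an effect only at larger amounts of compound), compound 1 gives > 50000 nM, which is a limit of the assay and not a number. Compound 2 `N#Cc1ccc(-c2ccc3[nH]c(=O)nc(-c4ccccc4)c3c2)cc1` carries a 4-cyanophenyl group in the same position; in this assay compound 2 gives > 50000 nM, again a limit. Compound 3 `Cn1nccc1-c1ccc2[nH]c(=O)nc(-c3ccccc3)c2c1` carries a 1-methyl-1H-pyrazol-5-yl group; in this assay compound 3 gives > 50000 nM, also a limit. Compound 3 therefore stands where the other two stand, at the limit of > 50000 nM in this assay, at which 3 of the 3 values shown sit. The steps a step that the two limits leave unreadable from compound 1 to compound 2, a step that the two limits leave unreadable from compound 1 to compound 3 and a step that the two limits leave unreadable from compound 2 to compound 3 are all unreadable in size, since every value involved is a limit.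

Compound 4 `O=c1nc(-c2ccccc2)c2cc(N3CCNCC3)ccc2[nH]1` differs from compound 3 by piperazin-1-yl in place of 1-methyl-1H-pyrazol-5-yl on an aromatic carbon. Within the data shown here, no measured step reaches into this change: the three measured steps only show that swapping one aromatic group for another at this position left every value at the limit. On that basis compound 4 is expected to behave no differently beyond the scatter, so the step that the limit leaves unreadable from compound 3 to compound 4 is estimated as flat. Compound 4 is estimated at 60000 nM, with a range from 30000 nM to 150000 nM, and most likely the assay again reports only a limit.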

Compound 4, half-maximal effective concentration: > 25000 nM
Compound 4: no number, only a limit; the forecaster's own chance of this, stated with the estimate: 85%; the middle value does not contradict the limit.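

In this assay compound 4 gives > 25000 nM, which is a limit of the assay and not a number. Among these compounds, the steps to compound 4 from compound 1, compound 2 and compound 3 cannot be read, so no new step emerges. The compounds shown leave open at what concentration any of the four would show an effect in this assay.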